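Replacing the side chain of compound 3 with a piperidine amide

A few compounds are considered here, and "the series" means these few. Any claim that something is new, unique, unknown or untested is made for them only; others in the source may bear on it.

Among the measured compounds shown here, in a functional assay on MDA-MB-231 cells (Homo sapiens) for antiproliferative activity, read by MTT assay, with a stated time of 24 h (a higher number here means a weaker inhibitor, a lower number a stronger inhibitor), compound 3 `CCCCc1oc2ccccc2c1C(=O)c1ccc(OCC(=O)N[C@H](C)c2ccccc2)cc1` gives 39000 nM, the only actual number among the three measured compounds. Compound 1 `CCCCc1oc2ccccc2c1C(=O)c1ccc(OCC(=O)N2CCOCC2)cc1` reads > 50000 nM, which is a limit of the assay and not a number. Compound 2 `CCCCc1oc2ccccc2c1C(=O)c1ccc(OCC(=O)NCc2ccccc2)cc1` reads > 50000 nM, which is also a limit.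

Compound 4 `CCCCc1oc2ccccc2c1C(=O)c1ccc(OCCCC(=O)N2CCCCC2)cc1` carries 2-((piperidin-1-yl)carbonyl)ethyl in place of (1-phenylethyl)carbamoyl on a saturated chain carbon bound to an oxygen on an aromatic ring.

For the measured compounds named here, no measured step makes this exact change, so the nearest ones must serve. The first is an at least 1.2-fold lower number from compound 1 to compound 3 (0.10 log units; that floor lies within the scatter), which replaces a ring amide with the amide found in compound 3. The second is an at least 1.2-fold lower number from compound 2 to compound 3 (0.10 log units; that floor lies within the scatter), which adds only a methyl. Both are known only as small floors, and a step that the two limits leave unreadable from compound 1 to compound 2 gives no size at all. Compound 4 gives up the (1-phenylethyl) group and has a ring on its carbonyl, as compound 1 does, so it looks closer to compound 1 than to compound 3. In this assay, no clear gain is therefore expected, and a reading at the limit is quite likely. The expected change is a 1.3-fold higher number from compound 3 to compound 4 (0.11 log units; within the scatter), which would be a slightly higher number at most. For compound 4 the estimated value is 50000 nM, with an expected range of 25000 nM to 100000 nM.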

Compound 4, half-maximal inhibitory concentration: 36000 nM
Estimate against measurement, compound 4: 1.4-fold (0.14 log units) above; the range from low to high includes it.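

In this assay, the exchange of (1-phenylethyl)carbamoyl for 2-((piperidin-1-yl)carbonyl)ethyl gives a 1.1-fold lower number from compound 3 to compound 4 (0.03 log units; within the scatter), so this position accepts the loss of the aromatic ring, the hydrogen-bond donor and the defined stereocentre with no readable change in the number. The steps to compound 4 from the weaker-reading end of the series, an at least 1.3-fold lower number from compound 2 to compound 4 (0.14 log units; that floor lies within the scatter) and an at least 1.3-fold lower number from compound 1 to compound 4 (0.14 log units; that floor lies within the scatter), are only floors, and neither shows a real gain from the new side chain. Compound 1 and compound 2 each sit at a limit of the assay rather than at a number, which keeps these two steps open-ended: the limit of > 50000 nM in this assay, at which 2 of the 4 values shown sit.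

The piperidine ring and the ethyl part of the new group enter together, so the compounds shown cannot separate what each contributes at this position. It also remains open whether a carboxylic acid or a simple amine at the end of this side chain would move the number beyond the scatter, since every compound shown ends in an amide.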